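The source may report more compounds than this note shows. Statements on the series, on what has been measured and on what is new or still open speak of the compounds shown alone.

Measured so far:
compound 1 `Cc1cc(C)cc(NC(=O)CN2CCC(c3cccc[n+]3[O-])CC2)c1`: 76%
compound 2 `COc1cc(C(=O)NCN2CCC(c3cccc[n+]3[O-])CC2)ccc1Cl`: 54%

Both compounds were tested in a functional assay on HEK293 cells for agonist activity at D(4) dopamine receptor (Homo sapiens), read by FLIPR; a lower number here means a smaller maximal response, a higher number a larger maximal response. Compound 1 gives 76%, the higher of the two numbers, and compound 2 gives 54%, a gap that lies beyond the usual scatter of repeated measurements. Compound 3 `Cc1cccc(C)c1NC(=O)CN1CCC(c2cccc[n+]2[O-])CC1` has not yet been measured. It has the same atoms as compound 1, joined differently: 2,6-dimethylphenyl in place of 3,5-dimethylphenyl on an amide-type nitrogen. The two compounds therefore share the same core and the same amide link, and differ only in the dimethylphenyl group on the amide-type nitrogen. For the measured compounds named here, no pair of measured compounds differs in just one place, so there is no measured step to guide how large this change might be. In this assay the expected step is a number 6 percentage points lower from compound 1 to compound 3 (within the scatter), a small shift that stays within the scatter, although a modest loss cannot be ruled out. Compound 3 is accordingly estimated to reach 70% in this assay, within a range from 50% to 90%.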

Compound 3, largest response reached (reported as efficacy), in percent of the reference or control that the assay uses: 68%
Estimate against measurement, compound 3: 2 percentage points above, and the stated range covers the measured number.
By their numbers in this assay, from the lowest: compound 2; then compounds 3 and 1 (each within the scatter of the next).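

In this assay, rearranging the two methyl groups from 3,5-dimethylphenyl to 2,6-dimethylphenyl on the amide-type nitrogen gives a number 8 percentage points lower from compound 1 to compound 3 (within the scatter), and this is the first step shown between two compounds that differ in one place. The atoms stay the same and only their arrangement on the aromatic ring changes, yet the maximal responses of the pair cannot be told apart, so at this position this change makes no difference that the assay can resolve. Nothing available here bears on why the two arrangements read alike.

From the compounds shown here alone, this single pair tests only one rearrangement of two methyl groups, so it remains open whether the response would also hold with a plain phenyl, a 4-methoxyphenyl or a cyclohexyl group on the same nitrogen. It also leaves open whether changes elsewhere in the molecule, such as a longer chain between the amide carbonyl and the shared core, would shift the maximal response by more than the usual scatter.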